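Thiazolyl for Imidazolyl on the Tetrazole of Compound 1

This account rests on a few compounds, and the source may have more. Where it says the series, first, only, none or still open, it means among the compounds named here.

Measured compounds: compound 1 `N#Cc1cccc(-n2nnc(-c3ncc[nH]3)n2)c1` gives 34 nM in an assay for binding affinity to metabotropic glutamate receptor 5 (Rattus norvegicus); on this read-out lower numbers stand for stronger inhibition and higher numbers for weaker inhibition; compound 2 `N#Cc1cc(F)cc(-n2nnc(-c3ncc[nH]3)n2)c1` gives 9.3 nM in this assay.

Of the two numbers, compound 1 has the higher one; the nearest measured neighbour is compound 2, reached by a step of a 3.7-fold lower number from compound 1 to compound 2 (0.56 log units; beyond the scatter) through fluoro in place of hydrogen on an aromatic carbon. The step to compound 3 `N#Cc1cccc(-n2nnc(-c3cscn3)n2)c1` is of another kind: 1,3-thiazol-4-yl in place of 1H-imidazol-2-yl on an aromatic carbon. For the measured compounds named here, no measured pair shows this exchange, so the single step from compound 1 to compound 2 bears on it only as a sign that changes of one group on this core can move the number modestly. Going by the values given here, with no direct precedent, the expectation is a step of no more than modest size in either direction, most likely within the scatter. Compound 3 is therefore expected to give 50 nM in this assay, with a range of 10 nM to 250 nM. The expected step from compound 1 to compound 3 is a 1.5-fold higher number from compound 1 to compound 3 (0.17 log units; within the scatter).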

Compound 3, inhibition constant: 157 nM
Compound 3: middle estimate off by 3.1-fold (0.50 log units), on the low side, and the stated range covers the measured number.
By their numbers in this assay, from the lowest: compound 2; then compound 1; then compound 3.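

Compound 3 shows that this position, on an aromatic carbon of a five-membered aromatic ring with 4 nitrogen, is sensitive to which ring it carries in this assay: the exchange gives a 4.6-fold higher number from compound 1 to compound 3 (0.66 log units; beyond the scatter). The earlier step concerned only fluoro in place of hydrogen on an aromatic carbon, and it lowered the number, whereas this change at a different place raises it. The two rings match in heavy atom count and ring size, yet 1H-imidazol-2-yl has 1 hydrogen-bond donor and 1,3-thiazol-4-yl has 0, and nothing available here ties the step to that or any other difference.

Open, on these data alone, is how an amine or a 1H-pyrazol-3-yl group would compare at this position. Also open, as far as these compounds go, is whether fluoro would lower the number on the core of compound 3 as it does on the core of compound 1.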